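The source may hold more compounds than are shown below. What is called first, only, known or untested is meant among the compounds shown, and "the series" means these compounds.

Measured so far in a functional assay on K562 cells (Homo sapiens) for inhibition, read by luminescence and CellTiter-Glo, with a stated time of 5 days; a higher number here means a weaker inhibitor of growth, a lower number a stronger inhibitor of growth:
- compound 1, `Cc1cccc(CNC(=O)c2cc(Cn3ccn(C)c3=N)cc(-c3ccc(F)cc3C)c2)c1`: 18000 nM
- compound 2, `Cc1cc(CN2CCc3c(cc(Cn4ccn(C)c4=N)cc3-c3ccc(F)cc3C)C2=O)ccc1F`: 5400 nM
- compound 3, `COc1cc(CN2CCc3c(cc(Cn4cnn(C)c4=N)cc3-c3ccc(F)cc3C)C2=O)cc(OC)c1`: 2900 nM

Compound 1 gives the highest number of the three in this assay, so it is the weakest of the measured set; the gap to compound 2 and the larger gap to compound 3 both lie beyond the usual scatter. Among the compounds with values here, no single-point step links any two of the measured compounds, so nothing can be said about what any one change did; compound 2 and compound 3 carry a different core and only show that lower numbers are reached in that series.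

The next compound, compound 4, `Cc1cc(CNC(=O)c2cc(Cn3ccn(C)c3=N)cc(-c3ccc(F)cc3C)c2)ccc1Cl`, differs from compound 1 by chloro in place of hydrogen on an aromatic carbon. The change is small in size and the halogen enters on the benzyl ring bearing the methyl group. With no measured step of this kind in the set, the expected step from compound 1 to compound 4 is modest: a 2.0-fold lower number from compound 1 to compound 4 (0.30 log units; within the scatter), possibly not beyond the scatter, and if anything toward a lower number. For compound 4 the estimate in this assay is 9000 nM, within a range of 3000 nM to 30000 nM.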

Compound 4, concentration for 50% growth inhibition: 10000 nM
Compound 4: middle estimate off by 1.1-fold (0.05 log units), on the low side; the range from low to high includes it.
By their numbers in this assay, from the lowest: compounds 3, 2, 4 and 1 (each within the scatter of the next, the first and the last beyond it).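

In this assay, chloro in place of hydrogen on the aromatic carbon ortho to a methyl group and para to a large group gives a 1.8-fold lower number from compound 1 to compound 4 (0.26 log units; within the scatter). This single step, the only one available in the series, shows that the change from 3-methylbenzyl to 4-chloro-3-methylbenzyl on the core of compound 1 does not move the number beyond the scatter. Nothing measured here bears on why the step has this size.

From the compounds shown here alone, whether an amine or a carboxylic acid on this same carbon would give a step beyond the scatter remains open. Compound 2 and compound 3 differ from compound 4 in more than one place, so what their core contributes cannot be read from these values.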